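Fluoro Substitution on the Anilide Ring in Two Cores

The source may report more compounds than this note shows. Statements on the series, on what has been measured and on what is new or still open speak of the compounds shown alone.

Compound 1, `O=C(Nc1ccc(Oc2ccnc3[nH]ccc23)cc1)c1nn(-c2ccc(Cl)c(F)c2)ccc1=O`, gives 2580 nM in a functional assay on A549 cells (Homo sapiens) for cytotoxicity, read by MTT assay, with a stated time of 72 h; a lower number here means a stronger inhibitor, a higher number a weaker inhibitor. Compound 2, `O=C(Nc1ccc(Oc2ccnc3[nH]ccc23)c(F)c1)c1nn(-c2ccc(Cl)c(F)c2)ccc1=O`, carries one change from it: fluoro in place of hydrogen on an aromatic carbon. In this assay compound 2 gives 10300 nM. This change made a step of a 4.0-fold higher number from compound 1 to compound 2 (0.60 log units; beyond the scatter), so the fluorinated analogue is the weaker inhibitor of the pair.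

Compound 3, `Cc1cc(=O)n(-c2ccccc2OC(F)(F)F)nc1C(=O)Nc1ccc(Oc2ncnc3c2ccn3C)cc1`, is built on a different core; the difference between the two cores is not broken down here. In this assay compound 3 gives 25200 nM, the highest number among the three measured compounds, and it stands beyond the scatter from both compound 1 and compound 2.

Compound 4, `Cc1cc(=O)n(-c2ccccc2OC(F)(F)F)nc1C(=O)Nc1ccc(Oc2ncnc3c2ccn3C)c(F)c1`, has not yet been measured. It differs from compound 3 by fluoro in place of hydrogen on an aromatic carbon, the same change, at a place described in the same words, as that from compound 1 to compound 2. Since that earlier change gave a step of a 4.0-fold higher number from compound 1 to compound 2 (0.60 log units; beyond the scatter), a step of similar direction is expected here, a 2.6-fold higher number from compound 3 to compound 4 (0.41 log units; beyond the scatter), although nothing shows that the new core responds in the same way. Compound 4 is therefore estimated at 65000 nM, within a range from 25000 nM to 170000 nM.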

Compound 4, half-maximal inhibitory concentration: > 60000 nM
Compound 4 gave a limit, no number; the forecaster's own chance of this, stated with the estimate: 25%; the middle value is on the limit's open side.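

In this assay compound 4 gives > 60000 nM, which is a limit of the assay and not a number. Fluoro in place of hydrogen on an aromatic carbon raised the number on the core of compound 1 and again on the core of compound 3, here with an at least 2.3-fold higher number from compound 3 to compound 4 (0.37 log units; beyond the scatter), so the direction of the change carried over from one core to the other in these two pairs: the same change on two cores in this assay, a 4.0-fold higher number (0.60 log units; beyond the scatter) from compound 1 to compound 2 and an at least 2.3-fold higher number (0.37 log units; beyond the scatter) from compound 3 to compound 4; the limit leaves it open whether they differ. Going by these compounds, the true size of the step on the second core stays unknown, and two pairs set no rule for the wider series, the more so as one of the values shown is not a number: the limit of > 60000 nM in this assay, at which 1 of the 4 values shown sits.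

The compounds shown leave open whether a nitrile in place of fluoro on that same aromatic carbon would move the number in the same direction. They also leave open whether an amine or a carboxylic acid added to the core of compound 3 would change its standing in this assay.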